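The source may report more compounds than this note shows. Statements on the series, on what has been measured and on what is new or still open speak of the compounds shown alone.

Measured in a functional assay on HCT-116 cells (Homo sapiens) for antiproliferative activity, read by MTT assay, with a stated time of 24 h; a higher number here means a weaker inhibitor, a lower number a stronger inhibitor:
Compound 1 `c1ccc(-c2noc(-c3ccncc3)n2)cc1`: > 1000000 nM
Compound 2 `COc1ccc(-c2noc(C3CCCN3)n2)cc1OC1CCCC1`: 185000 nM
Compound 3 `COc1cc(-c2noc(-c3ccncc3)n2)ccc1OCc1ccccc1`: > 1000000 nM

Compound 2 is the only one of the three with an actual number, 185000 nM. Compound 1 gives > 1000000 nM, which is a limit of the assay and not a number. Compound 3 gives > 1000000 nM, which is also a limit.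

Compound 4 `COc1ccc(-c2noc(-c3ccc(Cl)cc3)n2)cc1OC1CCCC1` differs from compound 2 in one place, with 4-chlorophenyl in place of pyrrolidin-2-yl on an aromatic carbon of a five-membered aromatic ring with 2 nitrogen and 1 oxygen (4-chlorophenyl in place of pyrrolidin-2-yl on an aromatic carbon). Among the measured compounds shown here, no measured pair shows this change on its own, so compound 2 at 185000 nM is the only number to start from. Compound 1 and compound 3 also carry an aromatic ring on that carbon, but they differ from compound 2 elsewhere too, so they offer only loose guidance. Still, the set holds (the limit of > 1000000 nM in this assay, at which 2 of the 3 values shown sit), so any expected shift in this assay leans toward weaker inhibition, with nothing expected beyond the usual scatter. The expected change is a 1.4-fold higher number from compound 2 to compound 4 (0.13 log units; within the scatter). For compound 4 the estimated value is 250000 nM, with an expected range from 60000 nM to 900000 nM.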

Compound 4, half-maximal inhibitory concentration: > 1000000 nM
Compound 4 was reported as a limit; the forecaster's own chance of this, stated with the estimate: 35%; at least 4.0-fold (0.60 log units) between middle value and limit.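

In this assay, among the compounds shown here, placing 4-chlorophenyl instead of pyrrolidin-2-yl on this aromatic carbon gives an at least 5.4-fold higher number from compound 2 to compound 4 (0.73 log units; beyond the scatter), the first change in the set that can be read on its own. Compound 4 gives > 1000000 nM, which is a limit of the assay and not a number, so the step sets only a minimum size for the change. This pair ties the measurable value of compound 2 to the group on this carbon, but the swap changes several things at once: a non-aromatic ring with one hydrogen-bond donor and one acceptor leaves, and a chlorine-bearing aromatic ring of carbon only, with neither, enters.

With so few numbers in the set, the size of the gap and any trend across groups at this carbon remain out of reach: the limit of > 1000000 nM in this assay, at which 3 of the 4 values shown sit.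

On these data alone, it also remains open whether the ring nitrogen of pyrrolidin-2-yl, its ring shape or the absence of the aromatic ring matters most, which a piperidine ring, an open-chain aminomethyl group or a cyclopentyl ring on this carbon could begin to separate.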